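The source may report more compounds than this note shows. Statements on the series, on what has been measured and on what is new or still open speak of the compounds shown alone.

Measured in an in vitro ADME assay on microsomes from liver (Rattus norvegicus) for metabolic stability, read by LC-MS, tested at 1 uM; a higher number here means faster removal of the compound, a lower number slower removal:
- compound 1 `CN(C)S(=O)(=O)c1ccc(F)c(C#Cc2cc(Cl)ccc2OCC(=O)O)c1`: < 10 mL.min-1.g-1, a limit
- compound 2 `COCCN(C)S(=O)(=O)c1ccc(C)c(C#Cc2cc(Cl)ccc2OCC(=O)O)c1`: 49 mL.min-1.g-1
- compound 3 `CCCS(=O)(=O)c1ccc(F)c(C#Cc2cc(Cl)ccc2OCC(=O)O)c1`: < 10 mL.min-1.g-1, a limit

Among the compounds with values here, compound 2 holds the only number in this set. Compound 1 and compound 3 share (the limit of < 10 mL.min-1.g-1 in this assay, at which 2 of the 3 values shown sit).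

Next is compound 4 `Cc1ccc(S(=O)(=O)N(C)C(C)C)cc1C#Cc1cc(Cl)ccc1OCC(=O)O`, which differs from compound 2 as follows: isopropyl in place of 2-methoxyethyl on a sulfonamide nitrogen. Within the data shown here, the one measured step, a different change on the sulfonyl sulfur, is a step that the two limits leave unreadable from compound 1 to compound 3. It therefore sets neither a size nor a direction for this change. The step expected in this assay is a 1.1-fold lower number from compound 2 to compound 4 (0.04 log units; within the scatter), none beyond the scatter. For compound 4 the estimate is 45 mL.min-1.g-1, with an expected range of 18 mL.min-1.g-1 to 100 mL.min-1.g-1.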

Compound 4, intrinsic clearance in microsomes: 64 mL.min-1.g-1
Compound 4: the middle estimate sits 1.4-fold (0.15 log units) below what was measured, and the stated range covers the measured number.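

Isopropyl in place of 2-methoxyethyl on a sulfonamide nitrogen gives a 1.3-fold higher number from compound 2 to compound 4 (0.12 log units; within the scatter) in this assay, the first step in this set with a readable size. At this nitrogen, the two chains cannot be told apart in this read-out, even though the oxygen of 2-methoxyethyl is lost. Nothing measured in this set accounts for the step.

On these data alone, whether a cyclopropyl group or a longer chain on this nitrogen would give a step beyond the scatter stays open. Within the data shown here, the step from compound 1 to compound 3 cannot be read, and no single-place step links either compound to compound 2 or compound 4.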